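Notes on the phenol-capped series: isopropyl ether analogue

A few compounds are considered here, and "the series" means these few. Any claim that something is new, unique, unknown or untested is made for them only; others in the source may bear on it.

Compound 1 `Cn1c(Cc2nn(C)c(=O)c3ccccc23)nnc1SCCCCCCCC(=O)Nc1ccc(O)cc1O` gives 17000 nM in an assay on isolated protein (Mus musculus) for inhibition of IL15-IL15 receptor (Homo sapiens), read by resazurin assay, with stated times of 30 min and 2.5 days; on this read-out higher numbers stand for weaker inhibition and lower numbers for stronger inhibition.
Compound 2 `Cn1c(Cc2nn(C)c(=O)c3ccccc23)nnc1SCCCCCCCC(=O)Nc1ccc(O)cc1` gives > 30000 nM in this assay.

Where compound 2 stands: its value is a limit of the assay and not a number, (the limit of > 30000 nM in this assay, at which 1 of the 2 values shown sits). Compound 3 `CC(C)Oc1ccc(NC(=O)CCCCCCCSc2nnc(Cc3nn(C)c(=O)c4ccccc34)n2C)cc1` differs from compound 2 by isopropyl in place of hydrogen on an oxygen on an aromatic ring; cut one bond further out, hydroxy to isopropoxy. Among the compounds with values here, the only measured step, an at least 1.7-fold higher number from compound 1 to compound 2 (0.24 log units; that floor lies within the scatter), removed a hydroxy from the aromatic ring and did not touch this oxygen, so it bears on the new change only loosely; it also started from a compound with a number and ended at a limit. Within the data shown here, no closer step exists. In this assay no shift beyond the scatter is expected, and compound 3 is expected to stay near the limit. For compound 3 the estimate is 40000 nM, ranging from 15000 nM to 100000 nM. The expected step is a step that the limit leaves unreadable from compound 2 to compound 3.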

Compound 3, half-maximal inhibitory concentration: 1100 nM
The estimate for compound 3 lay 36-fold (1.56 log units) above the measured number, outside the stated range (below it).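

On the oxygen on the aromatic ring, isopropyl in place of hydrogen brings an at least 27-fold lower number from compound 2 to compound 3 (1.43 log units; beyond the scatter) in this assay, so this position responds strongly to substitution, which the earlier hydroxy removal could not show. The value of compound 2 is a limit of the assay, so this step gives only a floor: the limit of > 30000 nM in this assay, at which 1 of the 3 values shown sits. Replacing the 2,4-dihydroxyphenyl group with 4-isopropoxyphenyl brings a 15-fold lower number from compound 1 to compound 3 (1.19 log units; beyond the scatter), so a free hydroxy on the ring is not required for the stronger inhibition seen here.

The compounds shown leave open whether the gain is particular to isopropyl or extends to other ethers on the same oxygen, such as methoxy or cyclopentyloxy. They also leave open whether it holds with a shorter chain or with an amine on the ring in place of the ether.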